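Working notes: from compound 1 to compound 3

The compounds below may be only part of what the source reports. "The series", "measured", "known", "first", "only" and "open" are said of these compounds alone.

Measured in a functional assay on A549 cells (Homo sapiens) for cytotoxicity, read by MTT assay, with a stated time of 72 h; on this read-out lower numbers stand for stronger inhibition and higher numbers for weaker inhibition:
- compound 1 `CC[S+]([O-])CCCCN=C=S`: 10200 nM
- compound 2 `[O-][S+](CCCCN=C=S)Cc1ccccn1`: 8330 nM

Compound 1 and compound 2 lie within the scatter of each other, so compound 1 holds no separate place on these numbers. Compound 3 `[O-][S+](CCCCN=C=S)Cc1cccs1` is still unmeasured. It carries thiophen-2-yl in place of methyl on a saturated chain carbon bound to a sulfur. Going by the values given here, no measured single-place step exists as a guide. With compound 1 at 10200 nM and compound 2 at 8330 nM, no change beyond the scatter is expected in this assay. The estimated step is a 1.4-fold lower number from compound 1 to compound 3 (0.13 log units; within the scatter). For compound 3 the expected value is 7500 nM, with an estimated range of 3500 nM to 15000 nM.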

Compound 3, half-maximal inhibitory concentration: 8410 nM
Compound 3: the middle estimate sits 1.1-fold (0.05 log units) below what was measured; measured number inside the range.
By their numbers in this assay, from the lowest: compounds 2, 3 and 1 (each within the scatter of the next).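

Read in this assay the change to thiophen-2-yl gives a 1.2-fold lower number from compound 1 to compound 3 (0.08 log units; within the scatter) and so provides the only single-place step at this position, on a saturated chain carbon bound to a sulfur. The position thus takes a five-membered aromatic ring in place of methyl with no shift beyond the scatter. Nothing available bears on why.

Open, as far as these compounds go, is whether an amine, a carboxylic acid or a longer chain at this place would also stay within the scatter. Also open, from the compounds shown here alone, is whether a phenyl ring would do so.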